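Quinoxaline Sulfones: A Repeated Swap at the Anilino Nitrogen

This account rests on a few compounds, and the source may have more. Where it says the series, first, only, none or still open, it means among the compounds named here.

Three compounds of one series were measured in a functional assay on PC-3 cells (Homo sapiens) for cytotoxicity, read by MTT assay, with a stated time of 72 h; a lower number here means a stronger inhibitor, a higher number a weaker inhibitor. Compound 1 `Nc1cccc(Nc2nc3ccccc3nc2S(=O)(=O)c2ccccc2)c1` gives 2150 nM. Compound 2 `O=S(=O)(c1ccccc1)c1nc2ccccc2nc1Nc1ccc(F)cc1` gives 14200 nM, and compound 3 `COc1ccc(S(=O)(=O)c2nc3ccccc3nc2Nc2cccc(N)c2)cc1` gives 8600 nM. The core of compound 3 differs from that of compound 1 by methoxy in place of hydrogen on an aromatic carbon, a change that moved the number a 4.0-fold higher number from compound 1 to compound 3 (0.60 log units; beyond the scatter).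

Compound 2 arises from compound 1 by 4-fluorophenyl in place of 3-aminophenyl on a nitrogen on an aromatic ring, and this step weakened the inhibitor: a 6.6-fold higher number from compound 1 to compound 2 (0.82 log units; beyond the scatter). Compound 4 `COc1ccc(S(=O)(=O)c2nc3ccccc3nc2Nc2ccc(F)cc2)cc1` has not yet been measured. It arises from compound 3 by 4-fluorophenyl in place of 3-aminophenyl on a nitrogen on an aromatic ring, the same change as that from compound 1 to compound 2, made on a core that already carries the methoxy group.

Because a 6.6-fold higher number from compound 1 to compound 2 (0.82 log units; beyond the scatter) was seen on the unsubstituted core, a step of similar direction and size is expected from compound 3, so that the change to compound 4 is estimated at a 5.2-fold higher number from compound 3 to compound 4 (0.72 log units; beyond the scatter). Compound 4 is therefore expected to give about 45000 nM in this assay, with a plausible span from 15000 nM to 130000 nM.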

Compound 4, half-maximal inhibitory concentration: 2200 nM
Beside the measured number, compound 4's estimate is 20-fold (1.31 log units) above it, and the stated range ends above it.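

On the core that carries the methoxy group, the swap to 4-fluorophenyl ran in the opposite direction in this assay, with a 3.9-fold lower number from compound 3 to compound 4 (0.59 log units; beyond the scatter), so the step seen on the core of compound 1 did not carry over: the same change on two cores in this assay, a 6.6-fold higher number (0.82 log units; beyond the scatter) from compound 1 to compound 2 and a 3.9-fold lower number (0.59 log units; beyond the scatter) from compound 3 to compound 4, 26-fold (1.41 log units) apart, beyond the scatter of two such steps. The methoxy change shows the same reversal when read the other way, with a 6.5-fold lower number from compound 2 to compound 4 (0.81 log units; beyond the scatter) where 4-fluorophenyl sits on the nitrogen, opposite in direction to its step where 3-aminophenyl sits there: the same change on two cores in this assay, a 4.0-fold higher number (0.60 log units; beyond the scatter) from compound 1 to compound 3 and a 6.5-fold lower number (0.81 log units; beyond the scatter) from compound 2 to compound 4, 26-fold (1.41 log units) apart, beyond the scatter of two such steps. Within these four compounds, the effect of each change therefore depends on the other, but this single set shows neither the reason for the reversal nor whether it extends to any other pair of groups.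

The compounds shown leave open whether a plain phenyl or a chlorophenyl on the nitrogen would follow 3-aminophenyl or 4-fluorophenyl. They also leave open whether an ethoxy group or a chlorine in place of the methoxy would reverse the swap in the same way.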